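The compounds below may be only part of what the source reports. "The series", "measured", "known", "first", "only" and "open" are said of these compounds alone.

Of the compounds shown here, three sharing one core have so far been measured in a physicochemical assay for lipophilicity; on this read-out lower numbers stand for lower lipophilicity and higher numbers for higher lipophilicity. Compound 1 (`COc1ccccc1C1=NC(c2ccccc2)CO1`) carries methoxy and gives 3.76 as its value. Compound 2 (`Fc1ccccc1C1=NC(c2ccccc2)CO1`) carries fluoro in that place and gives 3.51 as its value. Compound 3 (`Clc1ccccc1C1=NC(c2ccccc2)CO1`) carries chloro and gives 3.56 as its value. Compound 3 stands within the scatter of both others, with a number 0.05 log units higher from compound 2 to compound 3 (within the scatter) on one side and a number 0.20 log units lower from compound 1 to compound 3 (within the scatter) on the other, so the three cannot be ranked. The remaining comparison, a number 0.25 log units lower from compound 1 to compound 2 (within the scatter) as well, stays inside the same scatter.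

The next structure is compound 4 (`CSc1ccccc1C1=NC(c2ccccc2)CO1`), and methylsulfanyl in place of chloro on an aromatic carbon describes how it differs, with methylsulfanyl in place of chloro on an aromatic carbon, ortho to a large group. Methylsulfanyl is the sulfur counterpart of methoxy, so the nearest measured precedent is a number 0.20 log units lower from compound 1 to compound 3 (within the scatter) when read in reverse. The exchange of the two halogens, a number 0.05 log units higher from compound 2 to compound 3 (within the scatter) in size, offers little further guidance. A small rise in this assay is therefore expected, one that does not clearly leave the scatter. The estimated change is a number 0.24 log units higher from compound 3 to compound 4 (within the scatter) in this read-out. Compound 4 is estimated at 3.8 with an expected range from 3.45 to 4.15 around that figure.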

Compound 4, partition coefficient: 3.5
Compound 4: middle estimate off by 0.30 log units, on the high side; the measured number falls inside the stated range.
By their numbers in this assay, from the lowest: compounds 4, 2, 3 and 1 (each within the scatter of the next).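

On an aromatic carbon ortho to a large group, methylsulfanyl now joins methoxy, fluoro and chloro, and in this assay it separates from none of them: the exchange for chloro gives a number 0.06 log units lower from compound 3 to compound 4 (within the scatter) and the exchange for fluoro gives a number 0.01 log units lower from compound 2 to compound 4 (within the scatter) while the exchange for methoxy gives a number 0.26 log units lower from compound 1 to compound 4 (within the scatter) as the largest of the three. The last of these steps shows that the sulfur counterpart and the oxygen form of this group cannot be told apart here, and the first shows the same for a change that brings in 1 carbon and 1 sulfur where 1 chlorine stood, so all four groups at this position remain unranked. No independent measurement is available that would account for these readings.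

From the compounds shown here alone, how an amine, a carboxylic acid or a longer chain such as butoxy would read at this place in this assay stays open, and so does whether any group here can leave the scatter at all. The compounds shown also leave open whether these four groups would read alike on another carbon of the same ring, or with a different group elsewhere on the shared core.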